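Shifting One Chlorine on the Dichlorophenyl Group

A few compounds are considered here, and "the series" means these few. Any claim that something is new, unique, unknown or untested is made for them only; others in the source may bear on it.

Compound 1 `Cc1ccc(NC(=O)NC(=O)c2ccc(OCc3ccccc3F)cc2)cc1-c1nc2ccccc2[nH]1`: 2520 nM
Compound 2 `Cc1ccc(NC(=O)NC(=O)c2ccc(OCc3cccc(Cl)c3Cl)cc2)cc1-c1nc2ccccc2[nH]1`: > 100000 nM

Compound 2 stands at the limit of > 100000 nM in this assay, at which 1 of the 2 values shown sits, so its result is a limit and not a number. Compound 3 `Cc1ccc(NC(=O)NC(=O)c2ccc(OCc3ccc(Cl)cc3Cl)cc2)cc1-c1nc2ccccc2[nH]1` differs from compound 2 only in that (2,4-dichlorophenyl in place of 2,3-dichlorophenyl on a saturated chain carbon bound to an oxygen on an aromatic ring). Within the data shown here, the one measured step, an at least 39-fold higher number from compound 1 to compound 2 (1.59 log units; beyond the scatter), shows that exchanging 2-fluorophenyl for 2,3-dichlorophenyl drove the result past the limit; no measured step tells how moving one chlorine within a dichlorophenyl group acts. Compound 3 is therefore expected to stay weak, with an at least 1.6-fold lower number from compound 2 to compound 3 (0.22 log units; that floor lies within the scatter). Compound 3 is estimated at 60000 nM, within 10000 nM to 200000 nM.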

Compound 3, half-maximal inhibitory concentration: 2740 nM
The estimate for compound 3 lay 22-fold (1.34 log units) above the measured number, and the stated range ends above it.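

The placing of the chlorines matters at this position: with the same atoms, 2,4-dichlorophenyl in place of 2,3-dichlorophenyl in a functional assay on MGC-803 cells (Homo sapiens) for inhibition, read by MTT assay, with a stated time of 48 h (on this read-out lower numbers stand for stronger inhibition and higher numbers for weaker inhibition), gives an at least 36-fold lower number from compound 2 to compound 3 (1.56 log units; beyond the scatter). The result for compound 2 is a limit and not a number: the limit of > 100000 nM in this assay, at which 1 of the 3 values shown sits. Two chlorines on this ring therefore do not by themselves abolish inhibition, since 2,4-dichlorophenyl in place of 2-fluorophenyl gives only a 1.1-fold higher number from compound 1 to compound 3 (0.04 log units; within the scatter).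

Still open, as far as these compounds go, is whether a single chlorine, a methoxy group or an amine on this ring would match compound 3. From the compounds shown here alone, it is also open whether the sharp difference between compound 2 and compound 3 holds in other cell lines.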